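The source may hold more compounds than are shown below. What is called first, only, known or untested is meant among the compounds shown, and "the series" means these compounds.

Measured compounds in a physicochemical assay for solubility, at pH 7.4; a lower number here means a less soluble compound, a higher number a more soluble compound:

compound 1, `NS(=O)(=O)c1ccc(S(=O)(=O)CCCO)s1`, gives 14600 ug/mL
compound 2, `CC(=O)OCCCS(=O)(=O)c1ccc(S(N)(=O)=O)s1`, gives 920 ug/mL
compound 3, `NS(=O)(=O)c1ccc(CCCCCO)cc1`, gives 2600 ug/mL

Compound 1 and compound 2 differ in one place: acetyl in place of hydrogen on an oxygen on a saturated carbon. That step reads a 16-fold lower number from compound 1 to compound 2 (1.20 log units; beyond the scatter). Compound 4, `CC(=O)OCCCCCc1ccc(S(N)(=O)=O)cc1`, has not been measured in this assay; it stands to compound 3 as compound 2 stands to compound 1: acetyl in place of hydrogen on an oxygen on a saturated carbon. The place of the change is the same in both pairs, so it is the same change. How the core of compound 3 differs from the core of compound 1 is not broken down here, but compound 3 sits well below compound 1 in this assay.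

Compound 4 is expected to give a lower number than compound 3, a step of about a 13-fold lower number from compound 3 to compound 4 (1.11 log units; beyond the scatter), resting on the step from compound 1 to compound 2, a 16-fold lower number from compound 1 to compound 2 (1.20 log units; beyond the scatter). The estimate for compound 4 is 200 ug/mL, with a range from 60 ug/mL to 600 ug/mL.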

Compound 4, solubility: 1200 ug/mL
Compound 4: middle estimate off by 6.0-fold (0.78 log units), on the low side; the whole stated range lies below it.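

In this assay acetyl in place of hydrogen on an oxygen on a saturated carbon again gives a lower number: the step of a 2.2-fold lower number from compound 3 to compound 4 (0.34 log units; beyond the scatter) keeps the direction of the step of a 16-fold lower number from compound 1 to compound 2 (1.20 log units; beyond the scatter) but is clearly the smaller of the two. The direction therefore carried from one core to the other in this pair of pairs, while the size did not, and two cores cannot show how the change would read on a third. Nothing given here bears on why the size differs.

From the compounds shown here alone, the two cores differ in more than one place, so which part of them goes with the smaller step stays open. Also open, going by these compounds, is how an amine or a carboxylic acid in place of the acetoxy, or a longer chain, would read on either core.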